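Shrinking the selenium-bearing group of compound 1

The compounds below may be only part of what the source reports. "The series", "measured", "known", "first", "only" and "open" are said of these compounds alone.

Compound 1 (`COc1ccc(N(C)c2nc(C)nc3ccccc23)cc1C(=O)OCCC[Se]C#N`) gives 1140 nM in a functional assay on RKO cells (Homo sapiens) for inhibition, read by MTT assay, with a stated time of 48 h (a higher number here means a weaker inhibitor, a lower number a stronger inhibitor), and so belongs to the upper pair of the three measured numbers. Compound 2 (`Cc1nc(N(C)c2ccc(OCC[Se]C#N)cc2)c2ccccc2n1`) gives 652 nM in this assay and lies within the scatter of compound 1. Compound 3 (`Cc1nc(N(C)c2ccc([Se]C#N)c(Cl)c2)c2ccccc2n1`) gives 11 nM in this assay and lies far beyond the scatter from the other two.

Compound 4 (`COc1ccc(N(C)c2nc(C)nc3ccccc23)cc1C[Se]C#N`) keeps the core of compound 1 and differs in one place (a group of 4 heavy atoms (2 carbon, 1 nitrogen, 1 selenium; no ring) in place of a group of 9 heavy atoms (5 carbon, 1 nitrogen, 2 oxygen, 1 selenium; no ring), on an aromatic carbon) that is ortho to a methoxy group and meta to a large group. Among the compounds with values here, no measured pair isolates this change, since the three tested compounds differ from one another in more than one place. Within the data shown here, the only guide is loose: compound 3, with the smallest selenium-bearing group of the three, gives 11 nM as its number, while the larger groups of compound 1 and compound 2 give much higher numbers. Three compounds do not establish a rule, but a moderate drop in this assay beyond the scatter seems likely, stopping short of compound 3. The expected size of this change is a 5.2-fold lower number from compound 1 to compound 4 (0.71 log units; beyond the scatter) as estimated here. For compound 4 the estimated value is 220 nM with an expected range from 40 nM to 1000 nM in this wide estimate.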

Compound 4, half-maximal inhibitory concentration: 316 nM
For compound 4 the middle estimate is 1.4-fold (0.16 log units) below the measured one; the measured number falls inside the stated range.
By their numbers in this assay, from the lowest: compound 3; then compound 4; then compounds 2 and 1 (each within the scatter of the next).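

Within the data shown here, the step from compound 1 to compound 4 gives the first reading at this position, on an aromatic carbon ortho to a methoxy group and meta to a large group, as none of the earlier compounds differed from one another in one place only. In this assay, the group of 4 heavy atoms in place of the group of 9 heavy atoms gives a 3.6-fold lower number from compound 1 to compound 4 (0.56 log units; beyond the scatter), a modest step beyond the scatter, so at this position on the core of compound 1 the shorter selenium-bearing group gives the lower number. Nothing shown here accounts for the size or direction of this step.

Among these compounds, the single pair does not separate the loss of chain length from the loss of the carbonyl, as both go together in this one change. It also leaves open how a plain propyl chain ending in the same selenium and nitrile atoms would read at this position, and whether an amine or a carboxylic acid could stand there in place of the selenium-bearing group.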